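Enlarging the Aryl Group on a Fused Six-Ring Core

The compounds below may be only part of what the source reports. "The series", "measured", "known", "first", "only" and "open" are said of these compounds alone.

Compound 1 `Cc1ccc(-c2c3ccc4ccccc4c3nc3c2c(C)nc2c4ccccc4ccc32)cc1` — 72200 nM
Compound 2 `Cc1nc2c3ccccc3ccc2c2nc3c(ccc4ccccc43)c(-c3ccccc3)c12` — limit > 80000 nM

In a functional assay on HeLa cells (Homo sapiens) for cytotoxicity, read by MTT assay, with a stated time of 48 h (on this read-out lower numbers stand for stronger inhibition and higher numbers for weaker inhibition), compound 1 gives 72200 nM. For compound 2 the read-out is only a limit of this assay, > 80000 nM, and not a number. Between these two the single measured step, an at least 1.1-fold higher number from compound 1 to compound 2 (0.04 log units; that floor lies within the scatter), concerns hydrogen in place of methyl on an aromatic carbon, and it sits at the floor (the limit of > 80000 nM in this assay, at which 1 of the 2 values shown sits). Compound 3 `Cc1nc2c3ccccc3ccc2c2nc3c(ccc4ccccc43)c(-c3cccc4ccccc34)c12` differs from compound 2 by naphthalen-1-yl in place of phenyl on an aromatic carbon. Among the measured compounds shown here, no measured step involves a change of the aryl group, so nothing among the measured compounds bears directly on this change. Compound 3 is therefore expected to show no step beyond the scatter from compound 2, a number no higher from compound 2 to compound 3 (the limit leaves the size open). Compound 3 is estimated at 80000 nM, with a range from 40000 nM to 160000 nM, and a real chance that this assay again reports only a limit.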

Compound 3, half-maximal inhibitory concentration: 14900 nM
Beside the measured number, compound 3's estimate is 5.4-fold (0.73 log units) above it; the measured number lies below the stated range.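

In this assay, the aryl group on the aromatic carbon opposite the ring nitrogen proves able to shift the read-out: naphthalen-1-yl in place of phenyl gives an at least 5.3-fold lower number from compound 2 to compound 3 (0.72 log units; beyond the scatter), and naphthalen-1-yl in place of 4-methylphenyl gives a 4.8-fold lower number from compound 1 to compound 3 (0.69 log units; beyond the scatter). Among the compounds shown here, the only earlier step at this position, the loss of the methyl group, left a floor within the scatter, so going from one six-membered aromatic ring to two is the first change here with a step beyond it. Compound 2 gives only a limit, so the step from it is a floor and its true size stays open: the limit of > 80000 nM in this assay, at which 1 of the 3 values shown sits.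

The compounds shown leave open whether naphthalen-2-yl or a pyridine ring at this position would give a similar number. They also leave open how an amine or a carboxylic acid on the aryl group would alter it.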